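Phenyl for pyridin-2-yl on a tetrazole-linked hydroxamic acid

The compounds below may be only part of what the source reports. "The series", "measured", "known", "first", "only" and "open" are said of these compounds alone.

Compound 1 `O=C(NO)c1ccc(Cn2nnc(Cc3ccccc3)n2)cc1` gives 52 nM in an assay on Sf9 cells for inhibition of protein deacetylase HDAC6 (Homo sapiens), read by fluorescence; on this read-out lower numbers stand for stronger inhibition and higher numbers for weaker inhibition.
Compound 2 `O=C(O)c1cccc(-c2nnn(Cc3ccc(C(=O)NO)cc3)n2)c1` gives 12 nM in this assay.
Compound 3 `O=C(NO)c1ccc(Cn2nnc(-c3ccccn3)n2)cc1` gives 9 nM in this assay.

Compound 3 has the lowest number of the three; compound 2 sits within the scatter of it, while compound 1 lies well above. Compound 4 `O=C(NO)c1ccc(Cn2nnc(-c3ccccc3)n2)cc1` differs from compound 3 in one place: phenyl in place of pyridin-2-yl on an aromatic carbon. Among the compounds with values here, the only measured step at this position is a 5.8-fold lower number from compound 1 to compound 3 (0.76 log units; beyond the scatter), which swapped a benzyl for a ring attached directly to the shared core. Compound 4 keeps a directly attached ring, like compound 3 and compound 2, but loses the ring nitrogen. Whether that nitrogen matters cannot be read from these numbers. A small rise, possibly within the scatter, is therefore expected, a 1.7-fold higher number from compound 3 to compound 4 (0.22 log units; within the scatter). Compound 4 is estimated at 15 nM, with a range from 6 nM to 40 nM.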

Compound 4, half-maximal inhibitory concentration: 3 nM
Compound 4: the middle estimate sits 5.0-fold (0.70 log units) above what was measured; the whole stated range lies above it.
By their numbers in this assay, from the lowest: compound 4; then compounds 3 and 2 (each within the scatter of the next); then compound 1.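

Replacing pyridin-2-yl with phenyl gives a 3.0-fold lower number from compound 3 to compound 4 (0.48 log units; beyond the scatter) in this assay, so a ring nitrogen is not needed for strong inhibition at this position of the shared core. The unsubstituted phenyl also improves on the carboxy-bearing ring, with a 4.0-fold lower number from compound 2 to compound 4 (0.60 log units; beyond the scatter). Attaching the phenyl directly, rather than through the benzyl link, gives a 17-fold lower number from compound 1 to compound 4 (1.24 log units; beyond the scatter), the largest step in this set.

No measurement here offers a reason for these steps. From the compounds shown here alone, whether an amine, a methoxy group or a fluorine on the phenyl ring would preserve this inhibition remains open.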